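The source may report more compounds than this note shows. Statements on the series, on what has been measured and on what is new or still open speak of the compounds shown alone.

Measured in an ADME assay on HepG2 cells (Homo sapiens) for cytotoxicity; on this read-out higher numbers stand for an effect only at larger amounts of compound and lower numbers for an effect already at smaller amounts:
- Compound 1 `Cc1ccc(S(=O)(=O)N[C@@H](CC(=O)NC(C)(C)C)C(=O)NCCNC(=O)c2cccc(F)c2)cc1`: > 11000 nM
- Compound 2 `Cc1ccc(S(=O)(=O)N[C@@H](CC(=O)NC(C)(C)C)C(=O)NCCNC(=O)c2ccccc2O)cc1`: > 11000 nM

Compound 2 gives > 11000 nM, which is a limit and not a number. Compound 1 gives > 11000 nM, also a limit. Both compounds therefore sit at the same point, (the limit of > 11000 nM in this assay, at which 2 of the 2 values shown sit).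

Compound 3 `Cc1ccc(S(=O)(=O)N[C@@H](CC(=O)NC(C)(C)C)C(=O)NCCNC(=O)c2cccc(C(F)(F)F)c2)cc1` has 3-(trifluoromethyl)phenyl in place of 2-hydroxyphenyl on a carbonyl carbon.

Within the data shown here, the only measured step bearing on this change is a step that the two limits leave unreadable from compound 1 to compound 2. With no size to carry over from compound 1 to compound 2, no step beyond the usual scatter is expected in this assay, and no direction can be given. The expected change is a step that the limit leaves unreadable from compound 2 to compound 3. Compound 3 is most likely to be reported as a limit again. As a number, compound 3 is expected at about 13000 nM, with an estimated range from 6000 nM to 30000 nM.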

Compound 3, half-maximal effective concentration: > 11000 nM
Compound 3: only a limit was reported (the forecaster's own chance of this, stated with the estimate: 80%); the middle value is on the limit's open side.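

Compound 3 also gives only a limit, so no step can be read between compound 1, compound 2 and compound 3, and all three rest at one point: the limit of > 11000 nM in this assay, at which 3 of the 3 values shown sit.

The compounds shown leave open at what concentration each reaches its half-maximal effect in this assay, and whether swapping the group on the carbonyl carbon changes that concentration at all.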